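A few compounds are considered here, and "the series" means these few. Any claim that something is new, unique, unknown or untested is made for them only; others in the source may bear on it.

Measured compounds:
Compound 1 `C[C@H](NC(=O)CN(c1nc(Cl)nc2[nH]cnc12)C1CC1)C(=O)OCc1ccccc1` in a functional assay on the whole organism (Tail, strain ICR) with Mus musculus as the target, in the tail flick test, with a stated time of 150 min, at a dose of 25 umol/kg by the oral route (a higher number here means a stronger effect of the compound at the dose given, a lower number a weaker effect), gives 23%.
Compound 2 `O=C(CN(c1ncnc2c1ncn2C1CCCCO1)C1CC1)N[C@@H](CCC(=O)OCc1ccccc1)C(=O)OCc1ccccc1` in this assay gives 14.1%.
Compound 3 `C[C@H](NC(=O)CN(c1nc(Cl)nc2[nH]cnc12)C1CC1)C(=O)O` in this assay gives 14.7%.

Among the compounds with values here, compound 1 holds the highest of the three numbers, but its gaps to compound 3 and to compound 2 both lie within the scatter; the only measured step, a number 8.3 percentage points lower from compound 1 to compound 3 (within the scatter), concerns the ester and is within the scatter as well. Compound 4 `NC(=O)C[C@H](NC(=O)CN(c1nc(Cl)nc2[nH]cnc12)C1CC1)C(=O)OCc1ccccc1` differs from compound 1 by carbamoyl in place of hydrogen on a saturated chain carbon, two bonds along the chain from an amide-type nitrogen and a carbonyl carbon. Within the data shown here, no measured step touches this position, so nothing in the data predicts a change beyond the scatter. Compound 4 is therefore expected to lie near compound 1, with a step of a number 5 percentage points lower from compound 1 to compound 4 (within the scatter), at an estimated 18% and a range from 7% to 32%.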

Compound 4, a percentage reported as activity, at one dose (the size of the read-out at that dose, not a potency): 13.5%
Beside the measured number, compound 4's estimate is 4.5 percentage points above it; the measured number falls inside the stated range.
By their numbers in this assay, from the lowest: compounds 4, 2, 3 and 1 (each within the scatter of the next).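

Within the data shown here, compound 4 gives the first reading at this position: in this assay the change from methyl to carbamoylmethyl gives a number 9.5 percentage points lower from compound 1 to compound 4 (within the scatter). A group with a hydrogen-bond donor and acceptor can therefore stand on this saturated chain carbon without a step beyond the scatter. Nothing available bears on the cause of this result.

As far as these compounds go, whether a carboxylic acid, an amine or a longer chain at this carbon would give a step beyond the scatter remains open. So does whether carbamoyl gives a similar step when the benzyl ester is replaced by the free acid.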